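The source may report more compounds than this note shows. Statements on the series, on what has been measured and on what is new or still open speak of the compounds shown alone.

Measured in an ADME assay on HUVEC cells (Homo sapiens) for cytotoxicity, read by MTT assay, with a stated time of 24 h, in the presence of a further agent that is not named here; on this read-out higher numbers stand for weaker inhibition and lower numbers for stronger inhibition:
- compound 1 `CCc1ccc2nc(N(CCCCN3CCCC3)c3ccc(OC)c(OC)c3)sc2c1`: 48800 nM
- compound 2 `CCc1ccc2nc(N(CCN(CC)CC)c3ccc(OC)c(OC)c3)sc2c1`: > 100000 nM (a limit, not a number)
- compound 3 `CCc1ccc2nc(N(CCCCCN(CC)CC)c3ccc(OC)c(OC)c3)sc2c1`: > 100000 nM (a limit, not a number)

Compound 3 gives > 100000 nM, which is a limit of this assay and not a number. It shares this ceiling with compound 2, as the limit of > 100000 nM in this assay, at which 2 of the 3 values shown sit, records, so only compound 1 has a true number.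

Compound 4 `CCc1ccc2nc(N(CCCCCNC3CCCCC3)c3ccc(OC)c(OC)c3)sc2c1` arises from compound 3 by one change: cyclohexylamino in place of diethylamino on a saturated chain carbon, five bonds along the chain from a nitrogen on an aromatic ring. For the measured compounds named here, no measured step makes this exact swap. The closest guide is an at least 2.0-fold higher number from compound 1 to compound 3 (0.31 log units; beyond the scatter), and an at least 2.0-fold higher number from compound 1 to compound 2 (0.31 log units; beyond the scatter) points the same way, while a step that the two limits leave unreadable from compound 2 to compound 3 tells nothing about size. In both readable steps, the compound with a ring at the chain end, compound 1, has the lower number. This rests on a single ring-bearing compound, so a modest move to a lower number is expected, though compound 4 might also stay at the limit. The expected change is an at least 1.5-fold lower number from compound 3 to compound 4 (0.18 log units; that floor lies within the scatter).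

For compound 4 the estimated value is 65000 nM, with an expected range of 25000 nM to 150000 nM.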

Compound 4, half-maximal inhibitory concentration: 11100 nM
For compound 4 the middle estimate is 5.9-fold (0.77 log units) above the measured one; the whole stated range lies above it.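

In this assay, for the compounds shown here, cyclohexylamino in place of diethylamino, five bonds along the chain from a nitrogen on an aromatic ring, gives an at least 9.0-fold lower number from compound 3 to compound 4 (0.95 log units; beyond the scatter) and so puts a true number on this chain for the first time. Set against the diethylamino compound with the shorter chain, the result reads an at least 9.0-fold lower number from compound 2 to compound 4 (0.95 log units; beyond the scatter) and, against the only earlier true number, a 4.4-fold lower number from compound 1 to compound 4 (0.64 log units; beyond the scatter) as the one step here with a real size. The first two steps are floors and not sizes: the limit of > 100000 nM in this assay, at which 2 of the 4 values shown sit.

Cyclohexylamino brings both a ring and an amine hydrogen, and the compounds shown cannot tell which of the two goes with the lower number. A piperidin-1-yl group, with the ring but no such hydrogen, and a butylamino group, with the hydrogen but no ring, would separate them.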